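Acetyl in place of chloro: a first expectation

A few compounds are considered here, and "the series" means these few. Any claim that something is new, unique, unknown or untested is made for them only; others in the source may bear on it.

Measured in a functional assay on HaCaT cells (Homo sapiens) for antiproliferative activity, read by sulforhodamine B assay, with a stated time of 3 days; a higher number here means a weaker inhibitor, a lower number a stronger inhibitor:
Compound 1 `COC(=O)c1cc(CCc2cc(Cl)ccc2OC)ccc1O`: 6900 nM
Compound 2 `COC(=O)c1cc(CCc2cc(OC)ccc2Br)ccc1O`: 210 nM

Of these two, compound 1 has the higher number and so is the weaker inhibitor, and its gap to compound 2 lies beyond the scatter. Compound 3 `COC(=O)c1cc(CCc2cc(C(C)=O)ccc2OC)ccc1O` has acetyl in place of chloro on an aromatic carbon of compound 1 (acetyl in place of chloro on an aromatic carbon). Going by the values given here, no measured pair shows this kind of change on its own, so little guides the expectation, and no shift beyond the scatter is expected in this assay. The estimated change is a 1.2-fold higher number from compound 1 to compound 3 (0.06 log units; within the scatter). For compound 3, the expected value is 8000 nM, within an estimated range from 2000 nM to 30000 nM.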

Compound 3, half-maximal inhibitory concentration: 660 nM
For compound 3 the middle estimate is 12-fold (1.08 log units) above the measured one, and the stated range ends above it.
By their numbers in this assay, from the lowest: compound 2; then compound 3; then compound 1.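

In this assay, acetyl in place of chloro, on the carbon para to a methoxy group, gives a 10-fold lower number from compound 1 to compound 3 (1.02 log units; beyond the scatter) and so marks the stronger inhibitor of this pair. This position is therefore sensitive to what it carries, and the larger acetyl, with three heavy atoms against one, is accepted here without loss. The data shown offer no measurement that explains this gain.

Going by these compounds, whether the oxygen of the acetyl matters stays open, and an ethyl group at this position would address that. How an amine or a carboxylic acid would behave here is also unknown.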